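Chain length at the ether oxygen: from ester to carboxylic acid

The source may report more compounds than this note shows. Statements on the series, on what has been measured and on what is new or still open speak of the compounds shown alone.

Compound 1 `CCOC(=O)COc1ccc2c(=O)c(-c3ccc(O)cc3)coc2c1` carries an ethoxycarbonyl group on a saturated chain carbon bound to an oxygen on the aromatic ring of the shared core. In an assay (Cricetulus griseus) for inhibition of aldehyde dehydrogenase, mitochondrial (Homo sapiens) (a higher number here means a weaker inhibitor, a lower number a stronger inhibitor), compound 1 gives 130 nM. Compound 2 `O=C(O)CCCCCCCCCCCOc1ccc2c(=O)c(-c3ccc(O)cc3)coc2c1`, which bears a long carboxylic acid chain at the same oxygen, gives 130 nM in this assay, the same number at the digits shown as compound 1, so the two stand together as the lowest of the three. Compound 3 `C=CCOc1ccc2c(=O)c(-c3ccc(O)cc3)coc2c1`, with a short vinyl-bearing chain, gives 180 nM; the step of a 1.4-fold higher number from compound 1 to compound 3 (0.14 log units; within the scatter) stays within the scatter.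

Compound 4 `O=C(O)CCCCCCCOc1ccc2c(=O)c(-c3ccc(O)cc3)coc2c1` is the next compound. Compared with compound 1, (6-carboxyhexyl in place of ethoxycarbonyl on a saturated chain carbon bound to an oxygen on an aromatic ring). Among the measured compounds shown here, only one measured step bears on this kind of change at this position, the step from compound 1 to compound 3, and it was within the scatter; compound 2 shows that a much longer carboxylic acid chain at the same oxygen gives the same number as compound 1. Both point to little movement, so compound 4 is expected to sit close to compound 1, a step of a 1.1-fold higher number from compound 1 to compound 4 (0.03 log units; within the scatter), and its value is estimated at 140 nM, within 70 nM to 280 nM.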

Compound 4, half-maximal inhibitory concentration: 40 nM
For compound 4 the middle estimate is 3.5-fold (0.54 log units) above the measured one, and the stated range ends above it.
By their numbers in this assay, from the lowest: compound 4; then compounds 1, 2 and 3 (each within the scatter of the next).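

The earlier compounds shown here suggested that this oxygen tolerates very different groups with little change, but in this assay the 6-carboxyhexyl group breaks that picture, giving a 3.3-fold lower number from compound 1 to compound 4 (0.51 log units; beyond the scatter) and a 4.5-fold lower number from compound 3 to compound 4 (0.65 log units; beyond the scatter). A carboxylic acid at the end of the chain does not by itself give the lower number, since compound 2 also carries one and sits level with compound 1, while the shorter acid chain gives a 3.3-fold lower number from compound 2 to compound 4 (0.51 log units; beyond the scatter). Among these acids, then, chain length matters, although two lengths show only that they differ and not how the number follows length; no measurement here explains the gain.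

The compounds shown leave open how the number moves for carboxylic acid chains of lengths between those of compound 4 and compound 2, or for a shorter carboxylic acid chain on the same oxygen. They also leave open whether the acid end itself is needed, which the same chain as in compound 4 ending in an ethyl ester, an amide or an amine could test.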